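Cytotoxicity on Vero cells: methyl for fluoro step

This account rests on a few compounds, and the source may have more. Where it says the series, first, only, none or still open, it means among the compounds named here.

Measured in an ADME assay on Vero cells (Chlorocebus sabaeus) for cytotoxicity; on this read-out lower numbers stand for stronger inhibition and higher numbers for weaker inhibition:
- compound 1 `CCc1cnc(N2CCC(c3nc(COc4ccc(-n5cnnn5)cc4)cs3)CC2)nc1` gives a limit only, > 100000 nM.
- compound 2 `CCc1cnc(N2CCC(c3nc(COc4ccc(/C=C5\CC(=O)NC5=O)cc4F)cs3)CC2)nc1` gives a limit only, > 100000 nM.

Compound 2 sits at the limit of > 100000 nM in this assay, at which 2 of the 2 values shown sit. Going by the values given here, no step between measured compounds is available, and compound 1 and compound 2 show only the same limit. Compound 3 `CCc1cnc(N2CCC(c3nc(COc4ccc(/C=C5\CC(=O)NC5=O)cc4C)cs3)CC2)nc1` differs from compound 2 by methyl in place of fluoro on an aromatic carbon. For this change, the expected step is a number no higher from compound 2 to compound 3 (the limit leaves the size open), that is, none beyond the scatter in this assay. Compound 3 is estimated at 100000 nM, with a range from 50000 nM to 300000 nM, most likely again reported only as a limit.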

Compound 3, half-maximal inhibitory concentration: > 100000 nM
Compound 3 was reported as a limit; the forecaster's own chance of this, stated with the estimate: 85%; the middle value lies on the limit itself.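

Compound 2 and compound 3 both give only a limit in this assay, so no step can be read for methyl in place of fluoro: the limit of > 100000 nM in this assay, at which 3 of the 3 values shown sit.

The compounds shown leave open whether any concentration produces cytotoxicity in this series, and whether the two groups differ at all on this read-out.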